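A few compounds are considered here, and "the series" means these few. Any claim that something is new, unique, unknown or untested is made for them only; others in the source may bear on it.

The shared core of compound 1 `Cc1cccc2c1CC/C2=C\C(N)=O` is carried through the set with changes at the amide nitrogen and on the carbocyclic part. In a functional assay on the whole organism with Mus musculus as the target (on this read-out lower numbers stand for an effect already at smaller amounts and higher numbers for an effect only at larger amounts of compound), compound 1 gives > 100 mg/kg, which is a limit of the assay and not a number; this is the situation at the limit of > 100 mg/kg in this assay, at which 1 of the 3 values shown sits. Compound 2 `O=C(/C=C1\CCc2c(F)cc(F)cc21)NCCO` gives 100 mg/kg in this assay. Compound 3 `O=C(/C=C1\CCc2cc(F)cc(F)c21)NC1CC1`, which carries a cyclopropyl group on the amide nitrogen, gives 69 mg/kg in this assay; the values of compound 2 and compound 3 lie within the scatter of each other.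

Compound 4 `Cc1cccc2c1CC/C2=C\C(=O)NC1CC1` differs from compound 1 in one place: cyclopropyl in place of hydrogen on an amide-type nitrogen. Within the data shown here, no measured pair shows this change on the same core, and compound 3 carries the cyclopropyl group on a core that differs from compound 1 elsewhere, so the step cannot be sized from the numbers. Because compound 1 sits at > 100 mg/kg, a step toward smaller doses is expected, estimated as an at least 1.2-fold lower number from compound 1 to compound 4 (0.09 log units; that floor lies within the scatter). For compound 4 the estimate in this assay is 80 mg/kg, expected to lie between 40 mg/kg and 200 mg/kg.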

Compound 4, dose for half-maximal effect: 40 mg/kg
Estimate against measurement, compound 4: 2.0-fold (0.30 log units) above; the range from low to high includes it.
By their numbers in this assay, from the lowest: compounds 4, 3 and 2 (each within the scatter of the next, the first and the last beyond it).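

Among these compounds, on the core of compound 1, cyclopropyl in place of hydrogen on the amide-type nitrogen gives the first step that can be sized: in this assay it reads an at least 2.5-fold lower number from compound 1 to compound 4 (0.39 log units; beyond the scatter). Compound 1 gives > 100 mg/kg, which is a limit of the assay and not a number. The step is therefore a floor and its full size remains unknown, and it rests on a starting point that is itself a limit: the limit of > 100 mg/kg in this assay, at which 1 of the 4 values shown sits.

As far as these compounds go, whether this step belongs to cyclopropyl itself or would follow from any group on this nitrogen, such as methyl, a longer chain or a chain ending in an amine, stays open. From the compounds shown here alone, the steps among the other compounds cannot be read, as those compounds differ in more than one place, so it is also open whether cyclopropyl gives a similar step on the fluorinated cores.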